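A few compounds are considered here, and "the series" means these few. Any claim that something is new, unique, unknown or untested is made for them only; others in the source may bear on it.

Compound 1 `CO[C@H]1C=C(COC(C)=O)C(=O)[C@@H]2O[C@@](C)(OC)[C@](C)(OC)O[C@@H]12` is examined in an assay on isolated protein for inhibition of glutathione S-transferase P (Homo sapiens), read by spectrophotometry, with a stated time of 3 min (a higher number here means a weaker inhibitor, a lower number a stronger inhibitor), where compound 1 gives 62700 nM. Among the compounds with values here, this is the only number in hand for this assay. Compound 2 `CO[C@H]1C=C(COC(C)=O)C(=O)[C@H](O)[C@H]1O` reaches only a limit of the assay in this assay, > 100000 nM, which is the point described in the limit of > 100000 nM in this assay, at which 1 of the 2 values shown sits. Compound 3 `CO[C@]1(C)O[C@H]2[C@@H](OC/C=C(\C)CCC=C(C)C)C=C(COC(C)=O)C(=O)[C@@H]2O[C@@]1(C)OC` shares the core of compound 1 and differs from it in one place: 2,6-dimethylhepta-1,5-dien-1-yl in place of hydrogen on a saturated chain carbon bound to an oxygen on a saturated carbon, so that a methoxy becomes a (3,7-dimethylocta-2,6-dien-1-yl)oxy. Within the data shown here, no step between two measured compounds is at hand to set the size of such a change, so the expectation rests on compound 1 alone and on the limit seen for compound 2. The step from compound 1 to compound 3 in this assay is expected to be a modest gain that may not exceed the scatter a 2.1-fold lower number from compound 1 to compound 3 (0.32 log units; beyond the scatter). Compound 3 is therefore estimated at 30000 nM, with a range from 8000 nM to 100000 nM.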

Compound 3, half-maximal inhibitory concentration: 179000 nM
Beside the measured number, compound 3's estimate is 6.0-fold (0.78 log units) below it; measured number outside the range, above it.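

In this assay, replacing the methoxy with a (3,7-dimethylocta-2,6-dien-1-yl)oxy weakens inhibition, with a 2.9-fold higher number from compound 1 to compound 3 (0.46 log units; beyond the scatter). Within the data shown here, this is the only measured step at this place, on a saturated chain carbon bound to an oxygen on a saturated carbon, and it shows that this long chain lowers inhibition rather than raising it, while compound 3 still gives a number. Compound 2 differs from compound 1 in more than one place and gives only a limit of the assay, so it sets no size for this change: the limit of > 100000 nM in this assay, at which 1 of the 3 values shown sits.

Going by these compounds, whether the loss follows the length of the chain, or the double bonds in it, stays open, and an ethoxy or a saturated octyloxy at the same place would separate the two. On these data alone, it is equally open how a chain ending in an amine or a carboxylic acid would read here.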